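A few compounds are considered here, and "the series" means these few. Any claim that something is new, unique, unknown or untested is made for them only; others in the source may bear on it.

Measured compounds:
compound 1, `CCCCCCCCC(CCCCCCCCC(=O)OC)SCC(=O)NCC(=O)OC`: 29600 nM
compound 2, `CCCCCCCCC(CCCCCCCCC(=O)OC)SCC(=O)N[C@@H](C)C(=O)OC`: 103000 nM

Within the data shown here, in a functional assay on HepG2 cells (Homo sapiens) for cytotoxicity, read by MTT assay (on this read-out higher numbers stand for weaker inhibition and lower numbers for stronger inhibition), compound 2 stands as the higher of the two numbers, and its only neighbour is compound 1, reached by the step of a 3.5-fold higher number from compound 1 to compound 2 (0.54 log units; beyond the scatter). Compound 3, `CCCCCCCCC(CCCCCCCCC(=O)OC)SCC(=O)N[C@H](C(=O)OC)[C@@H](C)CC`, has not been measured. It differs from compound 2 by sec-butyl in place of methyl on a saturated chain carbon bound to an amide-type nitrogen and a carbonyl carbon. Among the measured compounds shown here, one measured step bears on this change: a 3.5-fold higher number from compound 1 to compound 2 (0.54 log units; beyond the scatter) placed a methyl on the same saturated chain carbon bound to an amide-type nitrogen and a carbonyl carbon, and the number rose by a modest amount beyond the scatter. Going further in that direction, from methyl to sec-butyl, the account therefore expects a further rise of the number for compound 3, likely of a modest size again, as a step of a 1.9-fold higher number from compound 2 to compound 3 (0.29 log units; within the scatter). The estimate for compound 3 in this assay is 200000 nM, expected to fall between 80000 nM and 500000 nM.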

Compound 3, half-maximal inhibitory concentration: 15300 nM
The estimate for compound 3 lay 13-fold (1.12 log units) above the measured number, outside the stated range (below it).
By their numbers in this assay, from the lowest: compounds 3 and 1 (each within the scatter of the next); then compound 2.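

In this assay, the saturated chain carbon bound to an amide-type nitrogen and a carbonyl carbon does not respond in one direction as the group on it grows: hydrogen to methyl gave a 3.5-fold higher number from compound 1 to compound 2 (0.54 log units; beyond the scatter), whereas methyl to sec-butyl reversed this, with a 6.7-fold lower number from compound 2 to compound 3 (0.83 log units; beyond the scatter). Hydrogen and sec-butyl at this place cannot be told apart, given a 1.9-fold lower number from compound 1 to compound 3 (0.29 log units; within the scatter), so among these three groups methyl alone stands apart. No available evidence accounts for this reversal.

On these data alone, it remains open whether a straight propyl chain, an isopropyl or a benzyl group at this carbon would track methyl or sec-butyl. Also open, as far as these compounds go, is how a carboxylic acid in place of the terminal methyl ester of the amino acid part would read in this assay.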